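Chloro in Place of Methyl: From Compound 1 to Compound 4

A few compounds are considered here, and "the series" means these few. Any claim that something is new, unique, unknown or untested is made for them only; others in the source may bear on it.

Measured so far:
compound 1 `Cc1ccc(COc2nc3ccccc3s2)cc1` gives 1.95%
compound 2 `Clc1ccccc1COc1nc2ccccc2s1` gives 14.6%
compound 3 `FC(F)(F)c1ccccc1COc1nc2ccccc2s1` gives 9.75%

In a functional assay on the whole organism with Mus musculus as the target, with a stated time of 1 h, at a dose of 100 mg/kg by the intraperitoneal route (on this read-out higher numbers stand for more inhibition at the one dose given (going by the name of the read-out) and lower numbers for less inhibition), compound 1 has the lowest number of the three, but only its gap to compound 2 lies beyond the scatter; compound 3 stands within the scatter of it. Compound 4 `Clc1ccc(COc2nc3ccccc3s2)cc1` differs from compound 1 by chloro in place of methyl on an aromatic carbon. Within the data shown here, the single measured step, a number 4.9 percentage points lower from compound 2 to compound 3 (within the scatter), concerns a different exchange and was within the scatter, so no step bears directly on this change. Compound 2 carries chloro and gives a higher number than compound 1, but that is one pair at another site. Compound 4 is therefore expected near 8%, from 0% to 20%, a step of a number 6.1 percentage points higher from compound 1 to compound 4 (within the scatter) expected to stay within the scatter.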

Compound 4, a percentage reported as inhibition, in the whole organism at one dose (the size of the read-out at that dose, not a potency): 82.9%
Compound 4: the middle estimate sits 74.9 percentage points below what was measured, outside the stated range (above it).
By their numbers in this assay, from the lowest: compounds 1, 3 and 2 (each within the scatter of the next, the first and the last beyond it); then compound 4.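

Exchanging methyl for chloro on an aromatic carbon, para to a large group, gives in this assay a change of a number 81 percentage points higher from compound 1 to compound 4 (beyond the scatter), so this one place can carry a large shift in the read-out. Among these compounds, the only earlier step, a number 4.9 percentage points lower from compound 2 to compound 3 (within the scatter), showed no change of that kind, though it concerned a different exchange. Nothing available explains the size of this shift. The compounds shown leave open whether chloro is special here, or whether fluoro, bromo, methoxy or an amine at the same place would give a similarly high number.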